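Trihydroxyphenyl in Place of Dichlorophenyl on a Chalcone-like Chain

A few compounds are considered here, and "the series" means these few. Any claim that something is new, unique, unknown or untested is made for them only; others in the source may bear on it.

Compound 2 `O=C(/C(=C\c1cccc(Cl)c1Cl)SCc1ccc(Cl)cc1)c1ccc(Cl)cc1` and compound 3 `O=C(/C(=C\c1cccc(Cl)c1Cl)SCc1ccc(Cl)cc1)c1ccc(Br)cc1` share one core and differ only by bromo in place of chloro on an aromatic carbon. In a functional assay on DU-145 cells (Homo sapiens) for inhibition, read by trypan blue exclusion, with a stated time of 96 h (a higher number here means a weaker inhibitor of growth, a lower number a stronger inhibitor of growth), compound 2 gives 10000 nM, and compound 3 gives 10000 nM; the step of no change at the digits printed from compound 2 to compound 3 (within the scatter) is therefore flat. Compound 1 `O=C(/C(=C\c1ccc(F)cc1C(F)(F)F)S(=O)(=O)Cc1ccc(Cl)c(Cl)c1)c1ccc(Cl)cc1` differs from both in several places at once, and in this assay compound 1 gives 1000 nM, a lower number than that of compound 2. Compound 2 thus stands with compound 3 at the highest of the three numbers, and farthest from compound 1.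

Compound 4 `O=C(/C(=C\c1c(O)cc(O)cc1O)SCc1ccc(Cl)cc1)c1ccc(Cl)cc1` is formed from compound 2 by the change (2,4,6-trihydroxyphenyl in place of 2,3-dichlorophenyl on a double-bonded chain carbon bound to a double-bonded chain carbon). Among the measured compounds shown here, no measured step touches this position: the single step recorded, no change at the digits printed from compound 2 to compound 3 (within the scatter), concerns a different aromatic carbon and shows no change, and compound 1 is separated from compound 2 by more than one change, so only its two values can be set side by side. The data give no ground to expect a step beyond the scatter, in either direction.

Compound 4 is therefore expected to come in near compound 2, at about 8000 nM, most likely between 2000 nM and 30000 nM, a step of a 1.3-fold lower number from compound 2 to compound 4 (0.10 log units; within the scatter) that is estimated to lie within the usual scatter.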

Compound 4, concentration for 50% growth inhibition: > 100000 nM
Compound 4: only a limit was reported; the forecaster's own chance of this, stated with the estimate: 15%; at least 12-fold (1.09 log units) between middle value and limit.
By their numbers in this assay, from the lowest: compound 1; then compounds 2 and 3 (each within the scatter of the next). At a limit, above all of these: compound 4.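

Among the compounds shown here, the position on the double-bonded chain carbon bound to a double-bonded chain carbon proves sensitive to the choice of aryl group in this assay, which the only earlier single change, on a different aromatic carbon, could not reveal, since it showed no change at the digits printed from compound 2 to compound 3 (within the scatter). Placing 2,4,6-trihydroxyphenyl there in place of 2,3-dichlorophenyl gives an at least 10-fold higher number from compound 2 to compound 4 (1.00 log units; beyond the scatter), the first single change among these compounds to reach beyond the scatter. The reading for compound 4 is a limit and not a number, so the step has no fixed size: the limit of > 100000 nM in this assay, at which 1 of the 4 values shown sits.

This one change removes both chloro groups and adds all three hydroxy groups, so the compounds shown do not separate the loss of the former from the arrival of the latter, nor do they tell how a single hydroxy group, a methoxy group or an amine on that phenyl ring would read in this assay. Also open, going by these compounds, is whether the same exchange would have a similar effect on the core of compound 1, which gives 1000 nM.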